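The source may report more compounds than this note shows. Statements on the series, on what has been measured and on what is new or still open speak of the compounds shown alone.

Compound 1, `CNC(=O)c1cccnc1NCCCN1CCN(c2ccccc2OC)CC1`, in a functional assay for antagonist activity at Alpha-1A adrenergic receptor (Oryctolagus cuniculus) (on this read-out lower numbers stand for tighter binding and higher numbers for weaker binding), gives 1 nM.
Compound 2, `CN(C)C(=O)c1cccnc1NCCCN1CCN(c2ccccc2OCC2CC2)CC1`, in this assay gives 0.159 nM.

Of these two numbers compound 2 holds the lower one; the gap to compound 1 lies beyond the usual scatter of the method. Compound 3, `CC(C)c1ccccc1N1CCN(CCCNc2ncccc2C(=O)N(C)C)CC1`, is compound 2 with isopropyl in place of cyclopropylmethoxy on an aromatic carbon. Among the compounds with values here, no pair of measured compounds shows a change of this kind, so the size of the step is uncertain; the number for compound 3 is expected to rise in this assay, toward weaker binding, by more than the scatter. For compound 3 the estimate is 1 nM, within 0.2 nM to 5 nM, meaning an expected step of a 6.3-fold higher number from compound 2 to compound 3 (0.80 log units; beyond the scatter).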

Compound 3, dissociation constant: 0.398 nM
The estimate for compound 3 lay 2.5-fold (0.40 log units) above the measured number, and the stated range covers the measured number.
By their numbers in this assay, from the lowest: compound 2; then compound 3; then compound 1.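

On the aromatic carbon ortho to a large group, swapping cyclopropylmethoxy for isopropyl in this assay gives a 2.5-fold higher number from compound 2 to compound 3 (0.40 log units; beyond the scatter) as a modest loss. Binding stays tight without the oxygen or the ring of the departing group, since compound 3 still gives 0.398 nM in this read-out. Nothing here shows why the step has this size.

Open, on these data alone, is how an amine or a carboxylic acid would fare at this place. A single pair also cannot show whether the same step would hold on a different amide.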